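The source may hold more compounds than are shown below. What is called first, only, known or untested is meant among the compounds shown, and "the series" means these compounds.

Measured compounds in the series:

- compound 1, `CCCCCNc1cc(Oc2c(OC)cc3cc(C#N)ccc3c2OC)nc(Nc2ccc(C#N)cc2)n1`; in an ADME assay on MT4 cells (Homo sapiens) for cytotoxicity, read by MTT assay, with a stated time of 5 days (on this read-out lower numbers stand for higher toxicity in this test and higher numbers for lower toxicity in this test), compound 1 gives > 125000 nM, a limit of the assay rather than a number.
- compound 2, `CCCC(C)Nc1cc(Oc2c(OC)cc3cc(C#N)ccc3c2OC)nc(Nc2ccc(C#N)cc2)n1`; in this assay compound 2 gives > 125000 nM, again a limit.
- compound 3, `COc1cc2cc(C#N)ccc2c(OC)c1Oc1cc(NCC(C)(C)C)nc(Nc2ccc(C#N)cc2)n1`; in this assay compound 3 gives > 125000 nM, also a limit.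

Compound 1 therefore stands at the assay ceiling, with no number of its own. The measured steps are a step that the two limits leave unreadable from compound 1 to compound 2, a step that the two limits leave unreadable from compound 1 to compound 3 and a step that the two limits leave unreadable from compound 2 to compound 3; none of the three can be sized, since (the limit of > 125000 nM in this assay, at which 3 of the 3 values shown sit).

The unmeasured compound 4, `CCCC(CCC)Nc1cc(Oc2c(OC)cc3cc(C#N)ccc3c2OC)nc(Nc2ccc(C#N)cc2)n1`, differs from compound 1 by 1-propylbutyl in place of pentyl on a nitrogen on an aromatic ring. The measured steps that bear on it all vary the same substituent on the same nitrogen, and every one of them left the read-out at the ceiling. The 1-methylbutyl group of compound 2 and the neopentyl group of compound 3 changed nothing readable.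

No direction can be assigned to the step in this assay; no step beyond the scatter is expected. The step from compound 1 to compound 4 is estimated as a step that the limit leaves unreadable from compound 1 to compound 4, and compound 4 is expected to give about 150000 nM in this assay, with a range from 60000 nM to 400000 nM, most likely reported again only as a limit.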

Compound 4, half-maximal cytotoxic concentration: > 125000 nM
Compound 4 gave a limit, no number; the forecaster's own chance of this, stated with the estimate: 80%; the middle value is on the limit's open side.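

The steps from compound 1, compound 2 and compound 3 to compound 4 in this assay cannot be read, since all four compounds give only a limit: the limit of > 125000 nM in this assay, at which 4 of the 4 values shown sit.

The compounds shown leave open where the actual half-maximal cytotoxic concentration of each of the four lies, and whether any amine substituent in this series gives a measurable value.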